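Swapping the aryl group on an isatin thiosemicarbazone

This account rests on a few compounds, and the source may have more. Where it says the series, first, only, none or still open, it means among the compounds named here.

Compound 1 `O=C1Nc2ccc(Br)cc2/C1=N/NC(=S)N/N=C/c1c(Cl)cccc1Cl`: 6730 nM
Compound 2 `COc1ccc(/C=N/NC(=S)N/N=C2\C(=O)Nc3ccc(C)cc32)cc1O`: 3190 nM
Compound 3 `Cc1ccc(O)c(/C=N/NC(=S)N/N=C2\C(=O)Nc3ccc(C)cc32)c1`: > 50000 nM

Of the compounds shown here, three have been tested in a functional assay on COS-7 cells (Chlorocebus aethiops) for inhibition, read by MTT assay; a lower number here means a stronger inhibitor, a higher number a weaker inhibitor. Compound 1 gives 6730 nM and compound 2 gives 3190 nM; the two share the thiosemicarbazone linker but differ both in the core substituent and in the aryl group. For compound 3 the assay reports only a limit, > 50000 nM, so its true value is not pinned to a number (the limit of > 50000 nM in this assay, at which 1 of the 3 values shown sits). Within the data shown here, the single one-place step measured so far is an at least 15-fold higher number from compound 2 to compound 3 (1.19 log units; beyond the scatter), a change of the aryl group on the shared core of compound 2.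

Compound 4 `Cc1ccc2c(c1)/C(=N/NC(=S)N/N=C/c1c(Cl)cccc1Cl)C(=O)N2` is not yet measured. It keeps the core of compound 3 and makes the change (2,6-dichlorophenyl in place of 2-hydroxy-5-methylphenyl on a carbon with a double bond to nitrogen). The same 2,6-dichlorophenyl group is present in compound 1, where it sits on a core that carries bromine rather than methyl and gives a definite number. Since the measured step from compound 2 to compound 3 was large and compound 3 sits at a limit, the reverse direction is expected for compound 4: a move toward a measurable value, of size an at least 8.3-fold lower number from compound 3 to compound 4 (0.92 log units; beyond the scatter). The estimate for compound 4 in this assay is 6000 nM, with a range from 2000 nM to 25000 nM.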

Compound 4, half-maximal inhibitory concentration: 3870 nM
For compound 4 the middle estimate is 1.6-fold (0.19 log units) above the measured one, and the stated range covers the measured number.
By their numbers in this assay, from the lowest: compounds 2, 4 and 1 (each within the scatter of the next, the first and the last beyond it). At a limit, above all of these: compound 3.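

In this assay, placing 2,6-dichlorophenyl on the carbon with a double bond to nitrogen, where compound 3 has 2-hydroxy-5-methylphenyl, gives an at least 12-fold lower number from compound 3 to compound 4 (1.11 log units; beyond the scatter), a step that starts from a limit of the assay held by compound 3 rather than from a number: the limit of > 50000 nM in this assay, at which 1 of the 4 values shown sits.

The replacement also shows that two quite different aryl groups can give matching results on this core, with a 1.2-fold higher number from compound 2 to compound 4 (0.08 log units; within the scatter), even though 3-hydroxy-4-methoxyphenyl carries a hydroxy group and 2,6-dichlorophenyl does not, so the presence of a hydroxy group alone does not separate compound 3 from the others. Compounds 1 and 2 differ in two places, so the core substituent could not be judged alone until now, and with the aryl group held constant the exchange of bromo for methyl gives a 1.7-fold lower number from compound 1 to compound 4 (0.24 log units; within the scatter), which does not distinguish the two.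

The compounds shown cannot tell whether the hydroxy group, the methyl group or their arrangement within 2-hydroxy-5-methylphenyl accounts for the result with compound 3. On these data alone, how an aryl group carrying an amine or a carboxylic acid, or a core carrying a nitro group, would behave in this assay also remains open.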